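This account rests on a few compounds, and the source may have more. Where it says the series, first, only, none or still open, it means among the compounds named here.

Of the compounds shown here, two built on the same shared core have been tested in a functional assay on SF-268 cells (Homo sapiens) for cytotoxicity, read by sulforhodamine B assay, with a stated time of 24 h; on this read-out lower numbers stand for stronger inhibition of growth and higher numbers for weaker inhibition of growth. Compound 1 `COc1ccc(C(=O)/C=C/c2cc3ccccc3[nH]c2=O)cc1` carries a methoxy group on its phenyl ring, and in this assay compound 1 gives 9770 nM. Among the measured compounds shown here, compound 2 `O=C(/C=C/c1cc2ccccc2[nH]c1=O)c1ccc(O)cc1` carries a hydroxy group on that same aromatic carbon, and in this assay compound 2 gives 23300 nM, which is the highest of the two numbers so far; the single measured step, hydrogen in place of methyl on an oxygen on an aromatic ring, reads a 2.4-fold higher number from compound 1 to compound 2 (0.38 log units; beyond the scatter), a modest change.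

Compound 3 `O=C(/C=C/c1cc2ccccc2[nH]c1=O)c1ccc(Cl)cc1` has not yet been measured. Against compound 2, the change is chloro in place of hydroxy on an aromatic carbon, that is, 4-hydroxyphenyl to 4-chlorophenyl. For the measured compounds named here, no measured step covers a chloro group at this position; the only step available, a 2.4-fold higher number from compound 1 to compound 2 (0.38 log units; beyond the scatter), concerns a different change on the same carbon, so it bears only loosely on compound 3. Compound 3 is therefore expected to land near 10000 nM, within an estimated range from 3000 nM to 35000 nM. That estimate amounts to a 2.3-fold lower number from compound 2 to compound 3 (0.37 log units; beyond the scatter).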

Compound 3, concentration for total growth inhibition: 63100 nM
For compound 3 the middle estimate is 6.3-fold (0.80 log units) below the measured one; the measured number lies above the stated range.
By their numbers in this assay, from the lowest: compound 1; then compound 2; then compound 3.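

This carbon responds to more than a change on the oxygen: replacing the whole hydroxy group with chloro in this assay gives a 2.7-fold higher number from compound 2 to compound 3 (0.43 log units; beyond the scatter), and replacing methoxy with chloro gives a 6.5-fold higher number from compound 1 to compound 3 (0.81 log units; beyond the scatter). Both steps lie beyond the scatter, so the chloro compound, compound 3, shows the weakest inhibition of growth of the three, and among these compounds the two groups joined through oxygen give the lower numbers. Nothing available explains why chloro reads higher than either oxygen-linked group, so the ranking stands only as an observation.

Three groups on one carbon of one shared core give an order but not a rule, so it remains open whether the oxygen link itself matters or only the particular groups shown. An amine or an ethoxy group on this same carbon would help to separate those two readings, and would show whether any group can bring the number below that of compound 1.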